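The source may report more compounds than this note shows. Statements on the series, on what has been measured and on what is new or still open speak of the compounds shown alone.

Working notes on the series. In an ADME assay on HeLa Rh cells (Homo sapiens) for cytotoxicity, read by microscopy (on this read-out higher numbers stand for lower toxicity in this test and lower numbers for higher toxicity in this test), compound 1 `COc1cc(CC(O)c2ccc(-c3ccc(C#N)cc3)cc2)c([N+](=O)[O-])cc1OC` gives 4700 nM and compound 3 `COc1cc(CC(O)c2ccc(-c3cccc(F)c3)cc2)c([N+](=O)[O-])cc1OC` gives 7400 nM. These two values lie within the scatter of each other, as a 1.6-fold higher number from compound 1 to compound 3 (0.20 log units; within the scatter) shows, so compound 3 stands level with compound 1 . Compound 2 `COc1cc(CC(O)c2ccc(-c3ccc(C=O)cc3)cc2)c([N+](=O)[O-])cc1OC` gives only a limit of the assay, > 245000 nM.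

The next change leads to compound 4 `COc1cc(CC(O)c2ccc(-c3ccccc3CO)cc2)c([N+](=O)[O-])cc1OC`, with 2-(hydroxymethyl)phenyl in place of 3-fluorophenyl on an aromatic carbon, para to a large group: 2-(hydroxymethyl)phenyl in place of 3-fluorophenyl on an aromatic carbon. Among the measured compounds shown here, no measured step makes this exact exchange. The nearest evidence comes from changes on the same terminal ring. One is small, a 1.6-fold higher number from compound 1 to compound 3 (0.20 log units; within the scatter), and two are large, an at least 52-fold higher number from compound 1 to compound 2 (1.71 log units; beyond the scatter) and an at least 33-fold lower number from compound 2 to compound 3 (1.51 log units; beyond the scatter), and both large steps involve compound 2 . The ring can therefore be silent or can shift the number strongly in this assay, and the data do not show which applies to the new group. The likeliest outcome is no change beyond the scatter, with some room towards higher numbers. The expected step is a 1.6-fold higher number from compound 3 to compound 4 (0.21 log units; within the scatter). For compound 4 the estimate is 12000 nM, with an expected range from 3500 nM to 50000 nM.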

Compound 4, half-maximal cytotoxic concentration: 24000 nM
Estimate against measurement, compound 4: 2.0-fold (0.30 log units) below; the measured number falls inside the stated range.
By their numbers in this assay, from the lowest: compounds 1 and 3 (each within the scatter of the next); then compound 4. At a limit, above all of these: compound 2.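

With 2-(hydroxymethyl)phenyl on this aromatic carbon, para to a large group, this assay shows a 3.2-fold higher number from compound 3 to compound 4 (0.51 log units; beyond the scatter) and a 5.1-fold higher number from compound 1 to compound 4 (0.71 log units; beyond the scatter), so a step beyond the scatter at this place no longer depends on compound 2 alone. The terminal ring is therefore not silent once formyl is set aside, although the two earlier compounds with 3-fluorophenyl and 4-cyanophenyl stay within the scatter of each other, and 4-formylphenyl remains apart, with an at least 10-fold lower number from compound 2 to compound 4 (1.00 log units; beyond the scatter). That last step has only a bound for its size, as compound 2 stands at a limit of the assay and not at a number: the limit of > 245000 nM in this assay, at which 1 of the 4 values shown sits.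

The exchange to 2-(hydroxymethyl)phenyl alters both the group on the terminal ring and its place on that ring, and the compounds shown do not separate the two. Also open, going by these compounds, is how 4-(hydroxymethyl)phenyl, or a terminal ring carrying a carboxylic acid or an amine, would stand in this assay.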